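Cytotoxicity notes: thiophene for pyridine on the shared core

This account rests on a few compounds, and the source may have more. Where it says the series, first, only, none or still open, it means among the compounds named here.

Measured in an ADME assay on LLC-MK2 cells (Macaca mulatta) for cytotoxicity, read by spectrophotometry and crystal violet staining, with a stated time of 4 days; a higher number here means that more compound is tolerated, a lower number that less compound is tolerated:
Compound 1 `CC(C)n1ncc2c(C(=O)Nc3ccccc3F)cc(-c3cccnc3)nc21`: 50000 nM.
Compound 2 `CC(C)n1ccc2c(C(=O)Nc3ccc(F)cc3)cc(-c3cccs3)nc21`: > 200000 nM, a limit of the assay and not a number.
Compound 3 `CC(C)n1ncc2c(C(=O)Nc3cccc(S(=O)(=O)N(C)C)c3)cc(-c3cccs3)nc21`: > 200000 nM, a limit of the assay and not a number.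

Among the compounds with values here, compound 1 is the only member of this set with a measured number; the other two values sit at the limit of > 200000 nM in this assay, at which 2 of the 3 values shown sit. Within the data shown here, no two measured compounds differ in a single place, so no anchored step is available.

Compound 4 `CC(C)n1ncc2c(C(=O)Nc3ccccc3F)cc(-c3cccs3)nc21` differs from compound 1 by thiophen-2-yl in place of pyridin-3-yl on an aromatic carbon. Compound 2 and compound 3 carry thiophen-2-yl and give only limits, whereas compound 1 carries pyridin-3-yl and gives a number.

In this assay a step toward a more tolerated compound is expected, a 3.0-fold higher number from compound 1 to compound 4 (0.48 log units; beyond the scatter). Compound 4 is estimated at 150000 nM, with a range from 50000 nM to 300000 nM.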

Compound 4, half-maximal cytotoxic concentration: 50000 nM
Beside the measured number, compound 4's estimate is 3.0-fold (0.48 log units) above it; the measured number falls inside the stated range.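

Thiophen-2-yl in place of pyridin-3-yl, on the aromatic carbon next to the ring nitrogen, gives no change at the digits printed from compound 1 to compound 4 (within the scatter) in this assay. Thiophen-2-yl alone therefore does not bring a compound to the limit: the limit of > 200000 nM in this assay, at which 2 of the 4 values shown sit.
Sharing thiophen-2-yl and the shared core with compound 4, compound 3 gives > 200000 nM, a limit of the assay and not a number.

On these data alone, it remains open whether the group on the amide nitrogen sets the tolerated concentration. Also open, as far as these compounds go, is whether phenyl or an aminopyridine on that aromatic carbon would depart from compound 4 in this assay.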